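The source may hold more compounds than are shown below. What is called first, only, known or untested is meant among the compounds shown, and "the series" means these compounds.

Compounds measured so far in a toxicity assay on L02 cells (Homo sapiens) for cytotoxicity, read by MTT assay, with a stated time of 72 h; a higher number here means a weaker inhibitor, a lower number a stronger inhibitor:
- compound 1, `O=C1c2c[n+]([O-])c3ccccc3c2C(=O)c2[nH]c3ccccc3c21` — 400 nM
- compound 2, `CN1CCN(CCCn2c3c(c4ccccc42)C(=O)c2c[n+]([O-])c4ccccc4c2C3=O)CC1` — 230 nM
- compound 3, `CCCN1CCN(CCCCn2c3c(c4ccccc42)C(=O)c2c[n+]([O-])c4ccccc4c2C3=O)CC1` — 6830 nM

Compound 3 gives the highest number of the three in this assay, beyond the scatter from both others; the step of a 30-fold higher number from compound 2 to compound 3 (1.47 log units; beyond the scatter) is the large one in the set, while a 1.7-fold lower number from compound 1 to compound 2 (0.24 log units; within the scatter) stays within the scatter. The step from compound 2 to compound 3 bundles two changes at once, a longer linker on the aromatic nitrogen and propyl in place of methyl on the piperazine nitrogen, so the data do not separate the two.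

Compound 4, `CN1CCN(CCCCn2c3c(c4ccccc42)C(=O)c2c[n+]([O-])c4ccccc4c2C3=O)CC1`, undoes one of them: hydrogen in place of ethyl on a saturated chain carbon bound to an amine nitrogen in a ring. Among the compounds with values here, what then remains between compound 2 and compound 4 is the linker length alone, and no measured pair isolates that change. Within the data shown here, the only step bearing on compound 4 is therefore a 30-fold higher number from compound 2 to compound 3 (1.47 log units; beyond the scatter), and only part of it can be ascribed to the alkyl group being removed here. A step downward from compound 3 beyond the scatter is expected, but not the full return to compound 2; the expected step is a 4.6-fold lower number from compound 3 to compound 4 (0.66 log units; beyond the scatter). For compound 4 the estimate in this assay is 1500 nM, with a range from 400 nM to 6000 nM.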

Compound 4, half-maximal inhibitory concentration: 80 nM
The estimate for compound 4 lay 19-fold (1.27 log units) above the measured number, and the stated range ends above it.
By their numbers in this assay, from the lowest: compound 4; then compounds 2 and 1 (each within the scatter of the next); then compound 3.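

In this assay, an 85-fold lower number from compound 3 to compound 4 (1.93 log units; beyond the scatter) comes from 4-methylpiperazin-1-yl in place of 4-propylpiperazin-1-yl alone, so a change of only two carbons at the far end of the side chain is enough to shift the number strongly. The longer linker does not account for the high number of compound 3, since with the methyl group kept it gives a 2.9-fold lower number from compound 2 to compound 4 (0.46 log units; beyond the scatter) in the opposite direction, and 4-(4-methylpiperazin-1-yl)butyl on the aromatic nitrogen gives a 5.0-fold lower number from compound 1 to compound 4 (0.70 log units; beyond the scatter) against the unsubstituted parent, whereas the propyl-linked chain gave a 1.7-fold lower number from compound 1 to compound 2 (0.24 log units; within the scatter) within the scatter. No measurement at hand accounts for the sensitivity of this assay to the propyl group.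

Open, from the compounds shown here alone, is whether the number climbs gradually with alkyl size or jumps only at propyl, which 4-ethylpiperazin-1-yl or unsubstituted piperazin-1-yl in place of 4-methylpiperazin-1-yl would help to settle. Also open, going by these compounds, is whether the drop seen with the butyl linker continues with a pentyl or hexyl linker, or whether the piperazine can give way to a morpholine.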